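Furan to pyridine on the carbonyl of an enone

A few compounds are considered here, and "the series" means these few. Any claim that something is new, unique, unknown or untested is made for them only; others in the source may bear on it.

Compound 2 `COc1ccc(/C=C/C(=O)c2ccco2)c(CN2CCCCC2)c1O` carries a furan-2-yl group on the carbonyl carbon of its enone. Among the measured compounds shown here, in a functional assay on KB cells (Homo sapiens) for cytotoxicity, read by sulforhodamine B assay, with a stated time of 3 days (a lower number here means that less compound is needed, a higher number that more compound is needed for the effect), compound 2 gives 5.18 ug/mL, the higher of the two numbers recorded so far, although the gap to the only other compound is within the scatter. That other compound, compound 1 `COc1ccc(/C=C/C(=O)c2cccs2)c(CN2CCCCC2)c1O`, gives 2.93 ug/mL in this assay, and the step of a 1.8-fold higher number from compound 1 to compound 2 (0.25 log units; within the scatter) corresponds to furan-2-yl in place of thiophen-2-yl on a carbonyl carbon.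

Compound 3 `COc1ccc(/C=C/C(=O)c2cccnc2)c(CN2CCCCC2)c1O` differs from compound 2 in one place: pyridin-3-yl in place of furan-2-yl on a carbonyl carbon. For the measured compounds named here, the only measured step that bears on this change is the exchange of one five-membered heteroaromatic ring for another on the same carbonyl carbon, a 1.8-fold higher number from compound 1 to compound 2 (0.25 log units; within the scatter), which stayed within the scatter. Going by the values given here, no measured pair exchanges a five-membered ring for a six-membered one, so nothing in the data points to a direction. On this basis the step to compound 3 is expected to be small, with no change beyond the scatter in this assay. Put as a step, the expectation reads a 1.0-fold lower number from compound 2 to compound 3 (0.02 log units; within the scatter). Compound 3 is accordingly estimated at 5 ug/mL, with a range from 2 ug/mL to 12.5 ug/mL.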

Compound 3, half-maximal effective concentration: 6.14 ug/mL
Compound 3: middle estimate off by 1.2-fold (0.09 log units), on the low side; low and high end bracket the measured number.
By their numbers in this assay, from the lowest: compounds 1, 2 and 3 (each within the scatter of the next, the first and the last beyond it).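

In this assay, the exchange of furan-2-yl for pyridin-3-yl on the carbonyl carbon gives a 1.2-fold higher number from compound 2 to compound 3 (0.07 log units; within the scatter), so this first move from a five-membered to a six-membered aromatic ring at this position does not separate compound 2 from compound 3. Among the compounds shown here, the comparison with the sulfur-containing ring tells a slightly different story: pyridin-3-yl in place of thiophen-2-yl gives a 2.1-fold higher number from compound 1 to compound 3 (0.32 log units; beyond the scatter), the first step in this small set to pass beyond the scatter, though only modestly. Compound 2 lies within the scatter of both neighbours, so the three rings form a shallow series in which only its two ends can be told apart, and that one step changes ring size and hetero atom together.

From the compounds shown here alone, it remains open whether a plain phenyl ring or a pyridin-4-yl ring on this carbonyl carbon would fall within the same narrow span. Going by these compounds, it is equally open whether an amine or a carboxylic acid carried on the ring would move the number further than any of these exchanges. Nothing available explains the small differences seen among these three compounds.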